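Cyclobutyl to Oxetane on the Amide Side Chain

The compounds below may be only part of what the source reports. "The series", "measured", "known", "first", "only" and "open" are said of these compounds alone.

In a functional assay on HEK293 cells for positive allosteric modulation of metabotropic glutamate receptor 5 (Rattus norvegicus), read by fluorescence and calcium flux (on this read-out higher numbers stand for larger maximal responses and lower numbers for smaller maximal responses), three compounds have been measured: compound 1 `C[C@@H](NC(=O)c1ccc(C#Cc2cccc(F)c2)cn1)C(C)(C)C` gives 66%; compound 2 `CC(C)CNC(=O)c1ccc(C#Cc2cccc(F)c2)cn1` gives 58.2%; compound 3 `O=C(NCC1CCC1)c1ccc(C#Cc2cccc(F)c2)cn1` gives 68.1%.

Compound 3 has the highest number of the three, but its lead is small: the nearest neighbour is reached by a number 2.1 percentage points higher from compound 1 to compound 3 (within the scatter) and the furthest by a number 9.9 percentage points higher from compound 2 to compound 3 (within the scatter), so all three sit within the usual scatter of one another.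

Compound 4 `CC1(CNC(=O)c2ccc(C#Cc3cccc(F)c3)cn2)COC1` differs from compound 3 in one place: 3-methyloxetan-3-yl in place of cyclobutyl on a saturated chain carbon bound to an amide-type nitrogen. The closest comparison is the earlier swap at the same carbon, a number 9.9 percentage points higher from compound 2 to compound 3 (within the scatter), which stayed within the scatter, as did a number 7.8 percentage points lower from compound 1 to compound 2 (within the scatter). Nothing here suggests a step beyond the scatter in this assay. Compound 4 is therefore expected to give about 66%, between 54% and 78%, an expected step of a number 2.1 percentage points lower from compound 3 to compound 4 (within the scatter).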

Compound 4, largest response reached (reported as efficacy), in percent of the reference or control that the assay uses: 60.4%
Beside the measured number, compound 4's estimate is 5.6 percentage points above it, and the stated range covers the measured number.
By their numbers in this assay, from the lowest: compounds 2, 4, 1 and 3 (each within the scatter of the next).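

In this assay, 3-methyloxetan-3-yl on this saturated chain carbon brings a ring oxygen and a hydrogen-bond acceptor into the side chain, yet the step stays within the scatter (a number 7.7 percentage points lower from compound 3 to compound 4 (within the scatter)). The comparisons with the two open-chain side chains also stay within it (a number 2.2 percentage points higher from compound 2 to compound 4 (within the scatter); a number 5.6 percentage points lower from compound 1 to compound 4 (within the scatter)), so this ring with a hetero atom fits the same narrow band as the all-carbon groups. No measurement here accounts for these numbers. On these data alone, whether an amine, a carboxylic acid or a longer chain at this place would move the response beyond the scatter remains open.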